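Compound 3 to compound 4: one aryl change on the shared core

The source may report more compounds than this note shows. Statements on the series, on what has been measured and on what is new or still open speak of the compounds shown alone.

In a functional assay on SMMC-7721 cells (Homo sapiens) for cytotoxicity, read by MTT assay, with a stated time of 72 h (a higher number here means a weaker inhibitor, a lower number a stronger inhibitor), compound 1 `O=C1C(=Cc2ccc(F)cc2)C(=O)N(c2ccc(Cl)cc2)N1c1ccc(Cl)cc1` gives 23300 nM, compound 2 `O=C1C(=Cc2ccc(Cl)cc2)C(=O)N(c2ccc(Cl)cc2)N1c1ccc(Cl)cc1` gives 30900 nM and compound 3 `COc1cc(C=C2C(=O)N(c3ccc(Cl)cc3)N(c3ccc(Cl)cc3)C2=O)ccc1O` gives 64900 nM, the highest of the three numbers. Compound 4 `COc1ccc(C=C2C(=O)N(c3ccc(Cl)cc3)N(c3ccc(Cl)cc3)C2=O)cc1` has not yet been measured. The change is 4-methoxyphenyl in place of 4-hydroxy-3-methoxyphenyl on a double-bonded chain carbon bound to a double-bonded ring carbon.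

Going by the values given here, three measured steps bear on this place. The step of a 1.3-fold higher number from compound 1 to compound 2 (0.12 log units; within the scatter) stays within the scatter, while the steps of a 2.8-fold higher number from compound 1 to compound 3 (0.44 log units; beyond the scatter) and a 2.1-fold higher number from compound 2 to compound 3 (0.32 log units; beyond the scatter) are modest and beyond it. Among the compounds with values here, no measured compound carries the 4-methoxyphenyl group, so no step isolates this change. The two modest steps only bound the likely size: compound 4 is expected to fall among the measured numbers, with a small move away from compound 3. The expected step is a 1.5-fold lower number from compound 3 to compound 4 (0.19 log units; within the scatter), towards a lower number. For compound 4 the estimate is 42000 nM, with an expected range of 19000 nM to 90000 nM.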

Compound 4, half-maximal inhibitory concentration: > 128000 nM
Compound 4 gave a limit, no number; the forecaster's own chance of this, stated with the estimate: 10%; middle value at least 3.0-fold (0.48 log units) away from the limit.
By their numbers in this assay, from the lowest: compounds 1 and 2 (each within the scatter of the next); then compound 3. At a limit, above all of these: compound 4.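

In this assay compound 4 gives a limit and no number: the limit of > 128000 nM in this assay, at which 1 of the 4 values shown sits. Methoxy in place of chloro gives an at least 4.1-fold higher number from compound 2 to compound 4 (0.61 log units; beyond the scatter) and methoxy in place of fluoro gives an at least 5.4-fold higher number from compound 1 to compound 4 (0.73 log units; beyond the scatter), both beyond the scatter, so on this aromatic carbon the 4-methoxyphenyl group does not hold the level of the 4-chlorophenyl and 4-fluorophenyl groups. Going from the 4-hydroxy-3-methoxyphenyl group to the 4-methoxyphenyl group gives an at least 1.9-fold higher number from compound 3 to compound 4 (0.29 log units; that floor lies within the scatter), a floor within the scatter, so this change brings no move back towards compound 1 or compound 2, though its full size stays unknown.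

Still open, on these data alone, is how far compound 4 lies past its limit, and so how large the step from compound 3 really is. Also open, as far as these compounds go, is how an amine or a carboxylic acid in this place on the aromatic ring would read on the shared core.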